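The source may report more compounds than this note shows. Statements on the series, on what has been measured and on what is new or still open speak of the compounds shown alone.

Measured compounds:
compound 1 `O=C1Nc2ccc(N3CCOC3=O)cc2C(CNC(=O)c2ccc(F)cc2)(C(F)(F)F)O1` — 67 nM
compound 2 `O=C1Nc2ccccc2C(CNC(=O)c2ccc(F)cc2)(C(F)(F)F)O1` — 95 nM

In an assay for inhibition of very long chain fatty acid elongase 6 (Homo sapiens) (a lower number here means a stronger inhibitor, a higher number a weaker inhibitor), compound 2 gives 95 nM, and the nearest number, that of compound 1, is 67 nM; the step of a 1.4-fold higher number from compound 1 to compound 2 (0.15 log units; within the scatter) lies within the scatter. Compound 3 `O=C1Nc2ccc(-n3ccccc3=O)cc2C(CNC(=O)c2ccc(F)cc2)(C(F)(F)F)O1` differs from compound 2 by a group of 7 heavy atoms (5 carbon, 1 nitrogen, 1 oxygen; one six-membered aromatic ring with 1 hetero atom) in place of a hydrogen atom, on an aromatic carbon. Going by the values given here, the one measured step that bears on this, a 1.4-fold higher number from compound 1 to compound 2 (0.15 log units; within the scatter), also concerns a group entering in place of a hydrogen atom on an aromatic carbon and was within the scatter, so no step beyond the scatter is expected here in this assay. Compound 3 is therefore estimated at 70 nM, between 30 nM and 160 nM, an expected step of a 1.4-fold lower number from compound 2 to compound 3 (0.13 log units; within the scatter).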

Compound 3, half-maximal inhibitory concentration: 106 nM
The estimate for compound 3 lay 1.5-fold (0.18 log units) below the measured number, and the stated range covers the measured number.
By their numbers in this assay, from the lowest: compounds 1, 2 and 3 (each within the scatter of the next).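

In this assay this aromatic carbon now carries a second ring-bearing group, a six-membered aromatic ring with 1 hetero atom, and it changes little against hydrogen (a 1.1-fold higher number from compound 2 to compound 3 (0.05 log units; within the scatter)) or against 2-oxo-1,3-oxazolidin-3-yl (a 1.6-fold higher number from compound 1 to compound 3 (0.20 log units; within the scatter)). Both steps lie within the scatter, so these three groups cannot be told apart at this position. Nothing available offers a reason for this. Going by these compounds, whether an amine or a carboxylic acid on this carbon would move the number beyond the scatter remains open.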